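The compounds below may be only part of what the source reports. "The series", "measured", "known", "first", "only" and "open" are said of these compounds alone.

In a functional assay on aorta (Rattus norvegicus) (on this read-out higher numbers stand for weaker inhibition and lower numbers for stronger inhibition), compound 1 `CC(C)(C)[Si](OCCc1ccc(=O)[nH]n1)(c1ccccc1)c1ccccc1` gives 56200 nM, compound 2 `CC(C)(C)[Si](OCCCc1ccc(=O)[nH]n1)(c1ccccc1)c1ccccc1` gives 78300 nM, and compound 3 `Cn1nc(CCO[Si](c2ccccc2)(c2ccccc2)C(C)(C)C)ccc1=O` gives 47000 nM. Compound 3 is not separated from either neighbour: there is a 1.2-fold lower number from compound 1 to compound 3 (0.08 log units; within the scatter) and a 1.7-fold lower number from compound 2 to compound 3 (0.22 log units; within the scatter), so the three sit together on this assay. Compound 4 `Cn1nc(CO[Si](c2ccccc2)(c2ccccc2)C(C)(C)C)ccc1=O` is unmeasured; it differs from compound 3 by a group of 8 heavy atoms (5 carbon, 2 nitrogen, 1 oxygen; one six-membered aromatic ring with 2 hetero atoms) in place of a group of 9 heavy atoms (6 carbon, 2 nitrogen, 1 oxygen; one six-membered aromatic ring with 2 hetero atoms), on a saturated chain carbon bound to an oxygen on an unsaturated carbon. For the measured compounds named here, the only step so far that changes the chain between the core and the oxygen is a 1.4-fold higher number from compound 1 to compound 2 (0.14 log units; within the scatter), a lengthening by one carbon that left the read-out unchanged; the step of a 1.7-fold lower number from compound 2 to compound 3 (0.22 log units; within the scatter) combines chain shortening with methyl on the aromatic nitrogen and also stayed in the scatter. Shortening the chain further, as in compound 4, is therefore expected to give no step beyond the scatter, and a 1.1-fold higher number from compound 3 to compound 4 (0.03 log units; within the scatter) is the expected size. Compound 4 is estimated at 50000 nM in this assay, with a range from 22000 nM to 110000 nM.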

Compound 4, half-maximal inhibitory concentration: 58400 nM
Estimate against measurement, compound 4: 1.2-fold (0.07 log units) below; measured number inside the range.
By their numbers in this assay, from the lowest: compounds 3, 1, 4 and 2 (each within the scatter of the next).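

In this assay, the group of 8 heavy atoms in place of the group of 9 heavy atoms, on a saturated chain carbon bound to an oxygen on an unsaturated carbon, now stands as a single change on the core bearing methyl on the aromatic nitrogen: a 1.2-fold higher number from compound 3 to compound 4 (0.09 log units; within the scatter) shows no separation at this position. The two other new steps, a 1.3-fold lower number from compound 2 to compound 4 (0.13 log units; within the scatter) and a 1.0-fold higher number from compound 1 to compound 4 (0.02 log units; within the scatter), also stay inside the scatter, so all four compounds sit together. Read on two cores, the change gives no separation either: the same change on two cores in this assay, a 1.7-fold lower number (0.22 log units; within the scatter) from compound 2 to compound 3 and a 1.0-fold higher number (0.02 log units; within the scatter) from compound 1 to compound 4, 1.7-fold (0.24 log units) apart, within the scatter of two such steps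

The substituents on silicon are the same in all four compounds, so what they contribute cannot be told from these data. On these data alone, whether a longer chain or an amine on that chain carbon would give a step beyond the scatter stays open.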